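The compounds below may be only part of what the source reports. "The series", "measured", "known", "first", "only" and "open" are said of these compounds alone.

Measured in a functional assay on PC-3 cells (Homo sapiens) for inhibition, read by sulforhodamine B assay, with a stated time of 72 h; a lower number here means a stronger inhibitor, a higher number a weaker inhibitor:
- compound 1 `Nc1sc(-c2ccc(Cl)cc2)c(-c2ccc(Cl)cc2)c1C(=O)Nc1ccccc1`: > 50000 nM (a limit of the assay)
- compound 2 `CC(C)(C)NC(=O)c1c(N)sc(-c2ccc(Cl)cc2)c1-c1ccc(Cl)cc1`: 15100 nM
- compound 3 `Nc1sc(-c2ccc(Cl)cc2)c(-c2ccc(Cl)cc2)c1C(=O)NC1CCCC1`: 21200 nM

Among the measured compounds shown here, compound 3 cannot be separated from the only other exact number, since the change is a 1.4-fold higher number from compound 2 to compound 3 (0.15 log units; within the scatter). Compound 1 gives only a limit, as the limit of > 50000 nM in this assay, at which 1 of the 3 values shown sits, records.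

The next compound is compound 4 `Nc1sc(-c2ccc(Cl)cc2)c(-c2ccc(Cl)cc2)c1C(=O)N1CCNCC1`, with piperazin-1-yl in place of cyclopentylamino on a carbonyl carbon. Three measured steps alter the same part of the molecule. Two start from the limit of compound 1: an at least 3.3-fold lower number from compound 1 to compound 2 (0.51 log units; beyond the scatter) and an at least 2.3-fold lower number from compound 1 to compound 3 (0.37 log units; beyond the scatter). For the measured compounds named here, the third, a 1.4-fold higher number from compound 2 to compound 3 (0.15 log units; within the scatter), is the only one between two exact numbers. On these data alone, none of them brings in piperazin-1-yl, so the direction of the change stays open, and in this assay no step beyond the scatter is expected. The expected change is a 1.1-fold lower number from compound 3 to compound 4 (0.03 log units; within the scatter). For compound 4 the estimated value is 20000 nM, with an expected range of 8000 nM to 50000 nM.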

Compound 4, half-maximal inhibitory concentration: 2710 nM
Compound 4: middle estimate off by 7.4-fold (0.87 log units), on the high side; the whole stated range lies above it.
By their numbers in this assay, from the lowest: compound 4; then compounds 2 and 3 (each within the scatter of the next). At a limit, above all of these: compound 1.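

In this assay, the group on the carbonyl carbon now moves the number beyond the scatter between exact values: a 7.8-fold lower number from compound 3 to compound 4 (0.89 log units; beyond the scatter) and a 5.6-fold lower number from compound 2 to compound 4 (0.75 log units; beyond the scatter), whereas a 1.4-fold higher number from compound 2 to compound 3 (0.15 log units; within the scatter). Compound 4 is thus the first compound shown to separate from the others, and piperazin-1-yl does so with the same count of heavy atoms as the cyclopentylamino it replaces. Measured against compound 1, the change reads an at least 18-fold lower number from compound 1 to compound 4 (1.26 log units; beyond the scatter), but that step starts from a limit, so it gives only a bound: the limit of > 50000 nM in this assay, at which 1 of the 4 values shown sits.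

The compounds shown leave open whether the lower number follows the second ring nitrogen or the six-membered ring itself, which piperidin-1-yl or morpholin-4-yl on the same carbonyl carbon would separate. They also leave open whether a methyl group on the free piperazine nitrogen would keep it.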